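The source may hold more compounds than are shown below. What is called first, only, known or untested is meant among the compounds shown, and "the series" means these compounds.

Compound 1 `O=C1CC(c2nc(-c3ccc(F)cc3)no2)CN1c1ccc(Cl)cc1` gives 1700 nM in an in vitro functional assay on HEK293-A cells for positive allosteric modulation of metabotropic glutamate receptor 5 (Homo sapiens), read by FLIPR and calcium flux; on this read-out lower numbers stand for an effect already at smaller amounts and higher numbers for an effect only at larger amounts of compound. Compound 2 `Cc1ccc(N2CC(c3nc(-c4cccc(C(F)(F)F)c4)no3)CC2=O)cc1` gives 3400 nM in this assay. Compound 3 `O=C1CC(c2nc(-c3ccccn3)no2)CN1c1ccc(F)cc1` reaches only a limit in this assay, reported as > 10000 nM.

Among the three measured compounds, compound 3 is the one without a number: its result is a limit, namely (the limit of > 10000 nM in this assay, at which 1 of the 3 values shown sits). A limit says only that no effect was seen up to the highest amount tested, so compound 3 cannot be placed on the same scale as the other two.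

Compound 4 `O=C1CC(c2nc(-c3cccc(F)c3)no2)CN1c1ccc(F)cc1` has not been measured yet. It differs from compound 3 in one place: 3-fluorophenyl in place of pyridin-2-yl on an aromatic carbon. Compound 1 and compound 2 both carry a carbon-only aromatic ring rather than pyridin-2-yl on the shared core, and both give numbers: compound 1 gives 1700 nM and compound 2 gives 3400 nM. Because compound 1 gives 1700 nM, the step from compound 3 to compound 4 is expected to run toward an effect at smaller amounts, roughly an at least 4.0-fold lower number from compound 3 to compound 4 (0.60 log units; beyond the scatter). Among the measured compounds shown here, no measured step of this kind exists, so the expectation is uncertain. Compound 4 is expected to give about 2500 nM in this assay, with a likely range from 800 nM to 9000 nM.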

Compound 4, half-maximal effective concentration: 88 nM
Beside the measured number, compound 4's estimate is 28-fold (1.45 log units) above it; the measured number lies below the stated range.
By their numbers in this assay, from the lowest: compound 4; then compounds 1 and 2 (each within the scatter of the next). At a limit, above all of these: compound 3.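

In this assay, among the compounds shown here, putting 3-fluorophenyl in place of pyridin-2-yl gives an at least 110-fold lower number from compound 3 to compound 4 (2.05 log units; beyond the scatter), the first comparison here between compounds that differ in one place. As far as these compounds go, it shows that the group on this aromatic carbon of the five-membered aromatic ring, between two ring nitrogen atoms, can by itself decide whether the compound gives a measurable number at all, and the true size of the step stays unknown, since compound 3 stands at a limit and not at a number: the limit of > 10000 nM in this assay, at which 1 of the 4 values shown sits. Compound 1 and compound 2 also carry carbon-only aromatic rings at this place, but each differs from compound 3 in more than one place, so neither could isolate this position.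

From the compounds shown here alone, this single change removes a ring nitrogen and adds a fluorine at once, so it remains open which of the two matters, and a plain phenyl ring at this place would separate them. Also open, going by these compounds, is how this position responds to other groups on the ring, such as a methoxy group, an amine or a carboxylic acid.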